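The compounds below may be only part of what the source reports. "The series", "measured", "known", "first", "only" and "open" are said of these compounds alone.

Measured compounds: compound 1 `C[C@@H](NCC1CCN(CCCc2c[nH]c3ccc(-n4cnnc4)cc23)CC1)c1ccccc1` gives 14 nM in an assay on CHO cells for displacement of a labelled ligand from 5-hydroxytryptamine receptor 1B (Homo sapiens); a higher number here means a weaker inhibitor, a lower number a stronger inhibitor; compound 2 `O[C@H]1Cc2ccccc2C1NC1CCN(CCCc2c[nH]c3ccc(-n4cnnc4)cc23)CC1` gives 300 nM; compound 3 `CC(=O)Nc1ccc([C@H](C)NCC2CCN(CCCc3c[nH]c4ccc(-n5cnnc5)cc34)CC2)cc1` gives 9.3 nM.

Compound 3 has the lowest of the three numbers in this assay, though its gap to compound 1 lies within the scatter; only compound 2 stands clearly apart. Compound 4 `c1ccc(NCC2CCN(CCCc3c[nH]c4ccc(-n5cnnc5)cc34)CC2)nc1` differs from compound 3 by pyridin-2-yl in place of 1-(4-acetamidophenyl)ethyl on an amine nitrogen. For the measured compounds named here, two steps bear on this. The step of a 1.5-fold lower number from compound 1 to compound 3 (0.18 log units; within the scatter) shows that a change on this amine nitrogen can leave the number unmoved, while the step of a 21-fold higher number from compound 1 to compound 2 (1.33 log units; beyond the scatter) shows that a larger rearrangement around the same nitrogen costs a great deal. The change to compound 4 is intermediate in kind, so compound 4 is expected to lose some potency, giving a 5.4-fold higher number from compound 3 to compound 4 (0.73 log units; beyond the scatter). For compound 4 the estimated value in this assay is 50 nM, in the range 15 nM to 200 nM.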

Compound 4, half-maximal inhibitory concentration: 3.3 nM
Compound 4: middle estimate off by 15-fold (1.18 log units), on the high side; the whole stated range lies above it.
By their numbers in this assay, from the lowest: compound 4; then compounds 3 and 1 (each within the scatter of the next); then compound 2.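

On this amine nitrogen, in this assay, pyridin-2-yl with its six heavy atoms and no stereocentre gives a lower number than either larger group, with a 2.8-fold lower number from compound 3 to compound 4 (0.45 log units; beyond the scatter) and a 4.2-fold lower number from compound 1 to compound 4 (0.63 log units; beyond the scatter). Neither the 1-(4-acetamidophenyl)ethyl nor the 1-phenylethyl group is therefore needed for a low number, and the distance from the indanyl compound grows to a 91-fold lower number from compound 2 to compound 4 (1.96 log units; beyond the scatter). Nothing measured here explains these steps.

Open, on these data alone, is whether a plain phenyl on this amine nitrogen would match pyridin-2-yl, and whether pyridin-3-yl or pyridin-4-yl would.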